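The source may hold more compounds than are shown below. What is called first, only, known or untested is meant among the compounds shown, and "the series" means these compounds.

Measured so far in a functional assay on DU-145 cells (Homo sapiens) for inhibition, read by trypan blue exclusion, with a stated time of 96 h (on this read-out lower numbers stand for stronger inhibition of growth and higher numbers for weaker inhibition of growth), as the read-out:

- Compound 1 `O=C(/C(=C\c1ccc(O)c([N+](=O)[O-])c1)SCc1ccc(Br)cc1)c1ccc(Br)cc1` gives 10000 nM as a number
- Compound 2 `O=C(/C(=C\c1ccc(O)c([N+](=O)[O-])c1)SCc1ccc(Br)cc1)c1ccc(O)cc1O` gives > 100000 nM as a limit of the assay and not a number

Among the measured compounds shown here, compound 1 therefore holds the only true number in the set, and compound 2 marks the only comparison. For the measured compounds named here, the one measured step, an at least 10-fold higher number from compound 1 to compound 2 (1.00 log units; beyond the scatter), puts 2,4-dihydroxyphenyl in place of 4-bromophenyl on a carbonyl carbon and lies beyond the scatter. Compound 3 `O=C(/C(=C\c1ccc(O)c([N+](=O)[O-])c1)S(=O)(=O)c1ccc(I)cc1)c1ccc(Br)cc1` keeps that 4-bromophenyl and changes another place, as (4-iodophenyl)sulfonyl in place of (4-bromobenzyl)sulfanyl on a double-bonded chain carbon bound to a carbonyl carbon and a double-bonded chain carbon shows: (4-iodophenyl)sulfonyl in place of (4-bromobenzyl)sulfanyl on a double-bonded chain carbon bound to a carbonyl carbon and a double-bonded chain carbon. Going by the values given here, the measured step does not touch this place, so it gives no direction here and shows only that one change can matter in this assay for this core. The expectation therefore starts from compound 1 at 10000 nM and assumes no shift beyond the scatter, with wide uncertainty either way. The expected change is a 1.3-fold lower number from compound 1 to compound 3 (0.10 log units; within the scatter) in this estimate. For compound 3 the estimated value is 8000 nM with an expected range of 1500 nM to 50000 nM in this assay.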

Compound 3, concentration for 50% growth inhibition: 25000 nM
Compound 3: the middle estimate sits 3.1-fold (0.49 log units) below what was measured; measured number inside the range.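

In this assay, (4-iodophenyl)sulfonyl in place of (4-bromobenzyl)sulfanyl on a double-bonded chain carbon bound to a carbonyl carbon and a double-bonded chain carbon gives a 2.5-fold higher number from compound 1 to compound 3 (0.40 log units; beyond the scatter). This shows that growth inhibition also responds at this position, which the earlier change on the carbonyl carbon left untouched, and that the new group still leaves compound 3 with a true number that can be sized, though with weaker inhibition of growth than compound 1. Compound 2, changed at the other place, gives only a limit of the assay and not a number: the limit of > 100000 nM in this assay, at which 1 of the 3 values shown sits.

The single step changes several things together, as sulfanyl becomes sulfonyl, benzyl becomes phenyl and bromine becomes iodine, so the compounds shown cannot say which of these carries the loss. They also leave open how this position would respond to an amine or a carboxylic acid, or to a longer chain between the sulfur and the ring, and whether the 4-bromobenzyl group paired with a sulfonyl would hold the number of compound 1.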